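Benzyl variation on the shared thioacetamide series

The source may report more compounds than this note shows. Statements on the series, on what has been measured and on what is new or still open speak of the compounds shown alone.

Compound 2 `COc1ccc(CN(C(=O)CSc2nc3ccccc3s2)c2cc(OC)c(OC)c(OC)c2)cc1N=[N+]=[N-]` holds the lowest of the three numbers measured in a functional assay on PC-3 cells (Homo sapiens) for antiproliferative activity, read by MTT assay, with a stated time of 48 h; a lower number here means a stronger inhibitor, a higher number a weaker inhibitor: compound 2 gives 14400 nM. Compound 1 `COc1ccc(CN(C(=O)CSc2nc3ccccc3s2)c2cc(OC)c(OC)c(OC)c2)cc1C` gives 34300 nM, and compound 3 `COc1cc(N(Cc2ccc(F)cc2)C(=O)CSc2nc3ccccc3s2)cc(OC)c1OC` gives 50800 nM. The measured steps are a 2.4-fold lower number from compound 1 to compound 2 (0.38 log units; beyond the scatter), a 1.5-fold higher number from compound 1 to compound 3 (0.17 log units; within the scatter) and a 3.5-fold higher number from compound 2 to compound 3 (0.55 log units; beyond the scatter).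

Compound 4 `COc1cc(N(Cc2ccc(Br)cc2)C(=O)CSc2nc3ccccc3s2)cc(OC)c1OC` differs from compound 2 in one place: 4-bromophenyl in place of 3-azido-4-methoxyphenyl on a saturated chain carbon bound to an amide-type nitrogen. The step that bears most directly on this change is a 3.5-fold higher number from compound 2 to compound 3 (0.55 log units; beyond the scatter), where a 4-fluorophenyl likewise took the place of the 3-azido-4-methoxyphenyl; that step was modest and beyond the scatter. The comparison of compound 1 with compound 3, a 1.5-fold higher number from compound 1 to compound 3 (0.17 log units; within the scatter), lay within the scatter, so there is no sign that one plain phenyl substituent differs much from another in this assay. Going by the values given here, for the 4-bromophenyl in compound 4 a step of similar size and direction to the one into compound 3 is therefore expected, estimated as a 3.1-fold higher number from compound 2 to compound 4 (0.49 log units; beyond the scatter). Compound 4 is expected to give 45000 nM in this assay, in the range 20000 nM to 100000 nM.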

Compound 4, half-maximal inhibitory concentration: > 80000 nM
Compound 4 ended at the assay's limit; the forecaster's own chance of this, stated with the estimate: 15%; middle value at least 1.7-fold (0.24 log units) from the limit.
By their numbers in this assay, from the lowest: compound 2; then compounds 1 and 3 (each within the scatter of the next). At a limit, above all of these: compound 4.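

Compound 4 gives a limit and not a number: the limit of > 80000 nM in this assay, at which 1 of the 4 values shown sits. With 4-bromophenyl on the saturated chain carbon bound to an amide-type nitrogen, the series shows an at least 5.5-fold higher number from compound 2 to compound 4 (0.74 log units; beyond the scatter) and an at least 2.3-fold higher number from compound 1 to compound 4 (0.36 log units; beyond the scatter), both beyond the scatter, whereas the 4-fluorophenyl of compound 3 stayed within the scatter of compound 1. The halogen exchange itself stays unresolved: bromo in place of fluoro on an aromatic carbon gives an at least 1.5-fold higher number from compound 3 to compound 4 (0.19 log units; that floor lies within the scatter), a floor within the scatter, so no difference between these two halogens can be claimed.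

From the compounds shown here alone, the true size of all three steps stays open, since each rests on a limit. Also open, going by these compounds, is how a benzyl carrying an amine or a carboxylic acid, or a longer chain at this place, would read in this assay.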